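The compounds below may be only part of what the source reports. "The series", "measured", "known", "first", "only" and "open" are said of these compounds alone.

Working notes on the enone series built on the shared core of compound 1 `CC1=C(/C=C/C(=O)/C=C/c2cccc(C(F)(F)F)c2)C(C)(C)CCC1O`. In a functional assay on LNCaP cells (Homo sapiens) for cytotoxicity, read by MTT assay, with a stated time of 72 h (on this read-out lower numbers stand for stronger inhibition and higher numbers for weaker inhibition), compound 1 gives 740 nM. Going by the values given here, compound 2 `CC1=C(/C=C/C(=O)/C=C/c2cc(C(F)(F)F)ccc2C(F)(F)F)C(C)(C)CCC1O` gives 3200 nM in this assay, and the step of a 4.3-fold higher number from compound 1 to compound 2 (0.64 log units; beyond the scatter) is the only single-change comparison recorded so far. Compound 3 `CC1=C(/C=C/C(=O)/C=C/c2ccccc2F)C(C)(C)CCC1O` gives 2900 nM in this assay; it stands second highest of the three numbers, within the scatter of compound 2 and beyond it relative to compound 1, whose number is lower.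

Compound 4 `CC1=C(/C=C/C(=O)/C=C/c2cc(C(F)(F)F)ccc2F)C(C)(C)CCC1O` differs from compound 3 by trifluoromethyl in place of hydrogen on an aromatic carbon. Among the compounds with values here, the one measured step that bears on this change, the addition of a trifluoromethyl to an already substituted ring from compound 1 to compound 2, raised the number modestly. Within the data shown here, the numbers for compound 1 and compound 3 differ in two places and give no single-change step. On this basis a small shift beyond the scatter in either direction is not clearly supported for compound 4 in this assay, and the expected step of a 1.3-fold lower number from compound 3 to compound 4 (0.12 log units; within the scatter) is set near zero. The estimate for compound 4 is 2200 nM, with a range from 700 nM to 7000 nM.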

Compound 4, half-maximal inhibitory concentration: 1700 nM
Estimate against measurement, compound 4: 1.3-fold (0.11 log units) above; low and high end bracket the measured number.
By their numbers in this assay, from the lowest: compound 1; then compounds 4, 3 and 2 (each within the scatter of the next).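

Trifluoromethyl in place of hydrogen on an aromatic carbon, para to a fluoro group, gives a 1.7-fold lower number from compound 3 to compound 4 (0.23 log units; within the scatter), so the rise seen with the earlier pair does not recur here. Fluoro in place of trifluoromethyl gives a 1.9-fold lower number from compound 2 to compound 4 (0.27 log units; within the scatter), whereas fluoro in place of hydrogen gives a 2.3-fold higher number from compound 1 to compound 4 (0.36 log units; beyond the scatter), the only new step beyond the scatter. The outcome of adding trifluoromethyl therefore differs with the group already on the ring, at least across these two pairs: the same change on two cores in this assay, a 4.3-fold higher number (0.64 log units; beyond the scatter) from compound 1 to compound 2 and a 1.7-fold lower number (0.23 log units; within the scatter) from compound 3 to compound 4, 7.4-fold (0.87 log units) apart, beyond the scatter of two such steps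

These numbers do not show why the two steps differ, or whether the difference extends beyond these four compounds. From the compounds shown here alone, how an amine or a carboxylic acid on this aromatic carbon would read against hydrogen, fluoro and trifluoromethyl also remains open.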